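This account rests on a few compounds, and the source may have more. Where it says the series, first, only, none or still open, it means among the compounds named here.

Of the compounds shown here, three built on one shared core have been measured in an assay on CHO cells for binding affinity to metabotropic glutamate receptor 2 (Rattus norvegicus); a higher number here means a weaker inhibitor, a lower number a stronger inhibitor. Compound 1 `N[C@]1(C(=O)O)[C@H]2[C@@H](C[C@H]1OCCCc1ccccc1)[C@]2(F)C(=O)O` gives 9.83 nM. Compound 2 `N[C@]1(C(=O)O)[C@H]2[C@@H](C[C@H]1OCc1cccc(Cl)c1)[C@]2(F)C(=O)O` gives 3.28 nM. Compound 3 `Nc1cccc(CO[C@@H]2C[C@@H]3[C@H]([C@]2(N)C(=O)O)[C@@]3(F)C(=O)O)c1` gives 15.4 nM, the highest of the three numbers: its gap to compound 1 lies within the scatter, while its gap to compound 2 lies beyond it. The steps seen so far are a 3.0-fold lower number from compound 1 to compound 2 (0.48 log units; beyond the scatter), a 1.6-fold higher number from compound 1 to compound 3 (0.19 log units; within the scatter) and a 4.7-fold higher number from compound 2 to compound 3 (0.67 log units; beyond the scatter).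

Compound 4 `N[C@]1(C(=O)O)[C@H]2[C@@H](C[C@H]1OCc1cccc(F)c1F)[C@]2(F)C(=O)O` differs from compound 3 by one change: 2,3-difluorophenyl in place of 3-aminophenyl on a saturated chain carbon bound to an oxygen on a saturated carbon. The measured step that bears most directly on this change is a 4.7-fold higher number from compound 2 to compound 3 (0.67 log units; beyond the scatter), in which a halogen on the aromatic ring gave way to an amino group; the new compound runs the other way, trading the aminophenyl for a halogenated phenyl. The step of a 3.0-fold lower number from compound 1 to compound 2 (0.48 log units; beyond the scatter) likewise shows a halogenated phenyl giving a lower number than the phenethyl of compound 1. Compound 4 is therefore expected to give a lower number than compound 3, by a step of about the size already seen, namely a 3.4-fold lower number from compound 3 to compound 4 (0.53 log units; beyond the scatter). The estimate for compound 4 in this assay is 4.5 nM, with a range from 1.5 nM to 14 nM. The range is kept wide, since the difluorophenyl is not the chlorophenyl of compound 2 and no difluorophenyl has yet been measured.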

Compound 4, inhibition constant: 4.25 nM
For compound 4 the middle estimate is 1.1-fold (0.02 log units) above the measured one; measured number inside the range.
By their numbers in this assay, from the lowest: compounds 2 and 4 (each within the scatter of the next); then compounds 1 and 3 (each within the scatter of the next).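

In this assay, the step of a 3.6-fold lower number from compound 3 to compound 4 (0.56 log units; beyond the scatter) shows that, on a saturated chain carbon bound to an oxygen on a saturated carbon, the lower number seen with 3-chlorophenyl is not tied to a chlorine, since 2,3-difluorophenyl also sits clearly below 3-aminophenyl. The step of a 1.3-fold higher number from compound 2 to compound 4 (0.11 log units; within the scatter) leaves these two halogenated phenyl groups indistinguishable in this assay, even though one carries a single chlorine and the other two fluorines. The step of a 2.3-fold lower number from compound 1 to compound 4 (0.36 log units; beyond the scatter) extends the comparison with phenethyl to a second halogenated phenyl, so that in this small set both halogenated phenyl compounds, compound 2 and compound 4, give lower numbers than compound 1 and compound 3.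

The compounds shown do not separate the contribution of each fluorine, or say whether an unsubstituted phenyl, a single fluorine, a methoxy group or a nitrile at this place would give a number nearer that of compound 4 or that of compound 3. Nothing available here accounts for why these groups fall in this order.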